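Aryl variation at the thiophene of the aminoketone series

The source may report more compounds than this note shows. Statements on the series, on what has been measured and on what is new or still open speak of the compounds shown alone.

Three members of the series have numbers in a functional assay on CCRF-CEM cells (Homo sapiens) for antiproliferative activity; a lower number here means a stronger inhibitor, a higher number a weaker inhibitor. Compound 2 `COc1cc(C(=O)c2sc(-c3ccncc3)cc2N)cc(OC)c1OC` gives 110 nM and stands lowest of the two numbers available. Compound 3 `COc1cc(C(=O)c2sc(-c3cc(OC)c(OC)c(OC)c3)cc2N)cc(OC)c1OC` gives 840 nM; the gap between compound 2 and compound 3 lies beyond the usual scatter. Compound 1 `COc1cc(C(=O)c2sc(-c3ccc(-c4ccccc4)cc3)cc2N)cc(OC)c1OC` reaches only the limit of this assay, > 10000 nM, so no number exists for it (the limit of > 10000 nM in this assay, at which 1 of the 3 values shown sits).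

Compound 4 `COc1cc(C(=O)c2sc(-c3ccc(C(F)(F)F)cc3)cc2N)cc(OC)c1OC` has not yet been measured in this assay. Relative to compound 2 the change is 4-(trifluoromethyl)phenyl in place of pyridin-4-yl on an aromatic carbon. For the measured compounds named here, no measured pair differs in exactly this way, so the size of the step can only be expected, not read off. The two compounds that carry a six-membered carbon-only ring at this place, compound 1 at the limit and compound 3 with its higher number, both sit above compound 2, while the ring with a nitrogen atom in compound 2 gives the lowest number.

On that basis the step from compound 2 to compound 4 in this assay is expected to go toward a higher number and beyond the scatter, a 14-fold higher number from compound 2 to compound 4 (1.13 log units; beyond the scatter). Compound 4 is estimated at 1500 nM, within a range of 300 nM to 8000 nM, with some chance that only a limit is returned.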

Compound 4, half-maximal inhibitory concentration: 270 nM
For compound 4 the middle estimate is 5.6-fold (0.74 log units) above the measured one; the measured number lies below the stated range.
By their numbers in this assay, from the lowest: compound 2; then compound 4; then compound 3. At a limit, above all of these: compound 1.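

In this assay, a carbon-only aromatic ring at this place, next to the ring sulfur, does not by itself bring a large loss, and the ring nitrogen of compound 2 is not required for a low number: a 2.5-fold higher number from compound 2 to compound 4 (0.39 log units; beyond the scatter) is a modest step, though it lies beyond the scatter and compound 2 keeps the lower number. Among the carbon-only rings, the group carried by the ring matters a great deal, with trifluoromethyl in place of phenyl giving an at least 37-fold lower number from compound 1 to compound 4 (1.56 log units; beyond the scatter). That step gives only a bound, since the value of compound 1 is not a number but a limit: the limit of > 10000 nM in this assay, at which 1 of the 4 values shown sits.

The compounds shown do not separate the contribution of the ring nitrogen from that of the group on the carbon-only ring, and an unsubstituted phenyl at this place would be the direct link between compound 2 and compound 4. Going by these compounds, it also stays open whether the tolerance seen with trifluoromethyl extends to a small group such as a chlorine atom or a methyl, or to a nitrile, and whether pyridin-3-yl matches pyridin-4-yl.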